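Swapping Isobutyl for Sec-Butyl on the Shared Core

The source may hold more compounds than are shown below. What is called first, only, known or untested is meant among the compounds shown, and "the series" means these compounds.

Measured in a functional assay on HepG2 cells (Homo sapiens) for antiproliferative activity, read by sulforhodamine B assay, with a stated time of 72 h; a higher number here means a weaker inhibitor, a lower number a stronger inhibitor
Compound 1 (`CC(C)[C@@H](NC(=O)OC(C)(C)C)C(=O)Nc1ccc2ncnc(Nc3cccc(Br)c3)c2c1`) gives > 50000 nM as a limit of the assay
Compound 2 (`CC(C)(C)OC(=O)NCC(=O)Nc1ccc2ncnc(Nc3cccc(Br)c3)c2c1`) gives 8300 nM as a number
Compound 3 (`CC(C)C[C@@H](NC(=O)OC(C)(C)C)C(=O)Nc1ccc2ncnc(Nc3cccc(Br)c3)c2c1`) gives 25000 nM as a number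

Of the two true numbers in this assay, the higher belongs to compound 3 (25000 nM). The measured step to it is a 3.0-fold higher number from compound 2 to compound 3 (0.48 log units; beyond the scatter) and marks it as the weaker of that pair. Compound 4 (`CC[C@H](C)[C@@H](NC(=O)OC(C)(C)C)C(=O)Nc1ccc2ncnc(Nc3cccc(Br)c3)c2c1`) has not been measured. It keeps the atoms of compound 3 but joins them differently, with sec-butyl in place of isobutyl (sec-butyl in place of isobutyl on a saturated chain carbon bound to an amide-type nitrogen and a carbonyl carbon).

Two steps at this same place bear on the change. The first, an at least 6.0-fold lower number from compound 1 to compound 2 (0.77 log units; beyond the scatter), shows that the group here can matter. The second, an at least 2.0-fold lower number from compound 1 to compound 3 (0.30 log units; that floor lies within the scatter), compares isopropyl with isobutyl, but its floor lies within the scatter, so it offers only a weak hint that compound 4 could drift toward compound 1. The expected step is therefore small and upward, a 1.8-fold higher number from compound 3 to compound 4 (0.26 log units; within the scatter), and it may not clear the scatter. Compound 4 is estimated at 45000 nM (expected range 20000 nM to 100000 nM).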

Compound 4, half-maximal inhibitory concentration: 34000 nM
Beside the measured number, compound 4's estimate is 1.3-fold (0.12 log units) above it, and the stated range covers the measured number.
By their numbers in this assay, from the lowest: compound 2; then compounds 3 and 4 (each within the scatter of the next). At a limit, above all of these: compound 1.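

In this assay, sec-butyl in place of isobutyl on this saturated chain carbon gives a 1.4-fold higher number from compound 3 to compound 4 (0.13 log units; within the scatter), so joining the same four carbons differently produces no change that can be told from the scatter. The sec-butyl group does stand clearly apart from hydrogen at this place, with a 4.1-fold higher number from compound 2 to compound 4 (0.61 log units; beyond the scatter), and compound 2 thus keeps the lowest number of the compounds with true values. The remaining step, an at least 1.4-fold lower number from compound 1 to compound 4 (0.16 log units; that floor lies within the scatter), has a floor within the scatter and rests on a limit of the assay, not on a number: the limit of > 50000 nM in this assay, at which 1 of the 4 values shown sits.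

The compounds shown leave open whether an amine or a carboxylic acid on this carbon would bring the number below that of compound 2. They also do not tell how a longer chain, such as n-hexyl, would fare here.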